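From pyrimidin-2-yl to oxan-4-yl on a carbonyl carbon

The source may hold more compounds than are shown below. What is called first, only, known or untested is meant among the compounds shown, and "the series" means these compounds.

Measured values in a functional assay on COR-L23 cells (Homo sapiens) for antiproliferative activity, read by CellTiter-Glo, with a stated time of 72 h (a lower number here means a stronger inhibitor, a higher number a weaker inhibitor), are as follows
- compound 1 `C[C@H](NC(=O)C1CCOCC1)c1ccc(NC(=O)N2CC(c3cccnc3)C2)cc1`: 58 nM
- compound 2 `C[C@@H](c1ccc(NC(=O)N2CC(c3ccc(N)nc3)C2)cc1)N1Cc2ccccc2C1=O`: 19 nM
- compound 3 `C[C@H](NC(=O)c1ncccn1)c1ccc(NC(=O)N2CC(c3ccc(N)nc3)C2)cc1`: 160 nM

Among these three, compound 3 has the highest number at 160 nM and is the weakest inhibitor, with its gaps to both others beyond the scatter. Compound 4 `C[C@H](NC(=O)C1CCOCC1)c1ccc(NC(=O)N2CC(c3ccc(N)nc3)C2)cc1` is compound 3 changed in one place: oxan-4-yl in place of pyrimidin-2-yl on a carbonyl carbon gives oxan-4-yl in place of pyrimidin-2-yl on a carbonyl carbon.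

Two observations bear on this change. Going by the values given here, the only measured step is an 8.4-fold higher number from compound 2 to compound 3 (0.93 log units; beyond the scatter) and it shows that the number can move clearly when the group on that saturated chain carbon changes, although that step did not involve oxan-4-yl. Compound 1 already carries the (oxan-4-yl)carbonyl group and gives 58 nM in this assay as a lower number than that of compound 3. However, those two compounds differ in more than this group, so the evidence is only indirect. A move toward a lower number, meaning a stronger inhibitor, is therefore expected. The expected change is a 4.6-fold lower number from compound 3 to compound 4 (0.66 log units; beyond the scatter) and this would be somewhat smaller than the measured step. Compound 4 is estimated at 35 nM with an expected range from 12 nM to 100 nM in this assay.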

Compound 4, half-maximal inhibitory concentration: 110 nM
Beside the measured number, compound 4's estimate is 3.1-fold (0.50 log units) below it, outside the stated range (above it).
By their numbers in this assay, from the lowest: compound 2; then compounds 1, 4 and 3 (each within the scatter of the next, the first and the last beyond it).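

In this assay, the direct swap on the carbonyl carbon gives a 1.5-fold lower number from compound 3 to compound 4 (0.16 log units; within the scatter). This lies within the scatter, so the assay does not separate pyrimidin-2-yl, an aromatic ring, from oxan-4-yl, a non-aromatic ring, at this place. Going by these compounds alone, the larger replacement, which takes away the whole group on the saturated chain carbon of compound 2, gives a 5.8-fold higher number from compound 2 to compound 4 (0.76 log units; beyond the scatter) and lies beyond the scatter, while amino in place of hydrogen on an aromatic carbon gives a 1.9-fold higher number from compound 1 to compound 4 (0.28 log units; within the scatter) and lies within it, so of these three single changes only the one on the saturated chain carbon clearly moves the number. Nothing available explains why the swap on the carbonyl carbon leaves the number within the scatter while the larger replacement does not.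

As far as these compounds go, only these two rings are compared on the carbonyl carbon, so it remains open whether a small group such as methyl, a longer open chain or a ring carrying an amine would also leave the number within the scatter. From the compounds shown here alone, it is also open whether amino in place of hydrogen on the aromatic carbon would give a similar step with pyrimidin-2-yl on the carbonyl carbon.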